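Methylating the sulfur of a thiol-bearing core

The compounds below may be only part of what the source reports. "The series", "measured", "known", "first", "only" and "open" are said of these compounds alone.

Measured compounds:
compound 1, `CCCc1nc(C)c2c(C(C)C)nnc(S)n12`: > 48000 nM
compound 2, `CCCc1nc(C)c2c(CC)nnc(S)n12`: > 48000 nM
compound 3, `CCCc1nnc(S)n2c(CCC)nc(C)c12`: > 48000 nM

In a functional assay for inhibition, with Homo sapiens as the target (on this read-out higher numbers stand for weaker inhibition and lower numbers for stronger inhibition), compound 1 gives > 48000 nM, which is a limit of the assay and not a number. Compound 2 in this assay gives > 48000 nM, again a limit. Compound 3 in this assay gives > 48000 nM, also a limit. All three values sit at the limit of > 48000 nM in this assay, at which 3 of the 3 values shown sit. The steps a step that the two limits leave unreadable from compound 1 to compound 2, a step that the two limits leave unreadable from compound 1 to compound 3 and a step that the two limits leave unreadable from compound 2 to compound 3 therefore cannot be read, and nothing in these three compounds shows whether any of the changes among them matters.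

Compound 4, `CCCc1nc(C)c2c(C(C)C)nnc(SC)n12`, differs from compound 1 by methyl in place of hydrogen on a sulfur. Within the data shown here, none of the measured steps touches the sulfur, so no measured step bears directly on this change, and compound 1 itself stands only at a limit. The step that the limit leaves unreadable from compound 1 to compound 4 is therefore expected to leave compound 4 where compound 1 stands, at or beyond the limit, with the direction unknown. Compound 4 is estimated to give 70000 nM in this assay, within a range of 8000 nM to 400000 nM.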

Compound 4, half-maximal inhibitory concentration: > 48000 nM
Compound 4: only a limit was reported; the forecaster's own chance of this, stated with the estimate: 80%; the middle value lies beyond the limit too.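

Compound 4 in this assay gives > 48000 nM and this is a limit of the assay, not a number. Among these compounds, compound 1 also stands at a limit, so no step between compound 1 and compound 4 can be read: the limit of > 48000 nM in this assay, at which 4 of the 4 values shown sit.

Going by these compounds, whether methyl in place of hydrogen on a sulfur changes inhibition at all remains open.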